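Thiophen-2-yl in Place of Furan-2-yl on Compound 2

The source may hold more compounds than are shown below. What is called first, only, known or untested is meant among the compounds shown, and "the series" means these compounds.

Two compounds built on a shared core have been run in a functional assay on K562 cells (Homo sapiens) for inhibition, read by thymidine incorporation, with a stated time of 48 h, tested at 10 ug/mL; a higher number here means more inhibition at the concentration tested (going by the name of the read-out), a lower number less inhibition. Compound 1, `C(#Cc1[nH]cnc2ncnc1-2)c1ccccc1`, gives 100% in this assay. Compound 2, `C(=C/c1[nH]cnc2ncnc1-2)\c1ccco1`, gives 24% in this assay, the lower of the two numbers, and its gap to compound 1 lies beyond the usual scatter. Compound 3, `C(=C/c1[nH]cnc2ncnc1-2)\c1cccs1`, is still to be measured. It differs from compound 2 in one place: thiophen-2-yl in place of furan-2-yl on a double-bonded chain carbon bound to a double-bonded chain carbon. Within the data shown here, no measured pair shows a change of this kind, so the numbers so far give no direct guide to how thiophen-2-yl in place of furan-2-yl will read in this assay. With nothing to anchor a direction, a step that stays within the scatter is expected. Compound 3 is therefore estimated to give 30% in this assay, with a range from 10% to 60%. This estimate means a step of a number 6 percentage points higher from compound 2 to compound 3 (within the scatter), expected to fall within the scatter.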

Compound 3, a percentage reported as inhibition, at one concentration (the size of the read-out at that concentration, not a potency): 50%
Compound 3: the middle estimate sits 20 percentage points below what was measured, within the range that was stated.
By their numbers in this assay, from the lowest: compound 2; then compound 3; then compound 1.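

In this assay, thiophen-2-yl in place of furan-2-yl on a double-bonded chain carbon bound to a double-bonded chain carbon gives a number 26 percentage points higher from compound 2 to compound 3 (beyond the scatter), the first step measured at this position. The two groups match in heavy atom count, ring size and counted hydrogen-bond donors and acceptors, and differ only in one ring atom, sulfur for oxygen, yet that single exchange moves the reading beyond the scatter. Nothing at hand accounts for the higher reading of the sulfur ring.

This single pair cannot tell whether the same exchange would give a like step on a triple-bonded chain. Going by these compounds, how a pyridin-2-yl ring or a carboxylic acid would read at this same place also remains open.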